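Swapping an amine for an ether in a cell assay

This account rests on a few compounds, and the source may have more. Where it says the series, first, only, none or still open, it means among the compounds named here.

Among the compounds with values here, in a functional assay on SK-OV-3 cells (Homo sapiens) for inhibition, read by CCK-8 assay, with a stated time of 70 h (on this read-out higher numbers stand for weaker inhibition and lower numbers for stronger inhibition), compound 2 `c1ccc(COc2ccc(OCCOCCNC3CCCC3)cc2)cc1` gives 24800 nM, one of only two numbers measured so far, and the other sits within the scatter of it. That other is compound 3 `O=[N+]([O-])c1ccc(COc2ccc(OCCOCCNC3CCCC3)cc2)cc1`, which gives 20300 nM; the step of a 1.2-fold lower number from compound 2 to compound 3 (0.09 log units; within the scatter) lies within the scatter. Compound 1 `c1ccc(COc2ccc(OCCOCCNc3ccccc3)cc2)cc1` reaches only a limit of the assay, > 100000 nM, as noted in the limit of > 100000 nM in this assay, at which 1 of the 3 values shown sits. The step of an at least 4.0-fold lower number from compound 1 to compound 2 (0.60 log units; beyond the scatter) is at least modest. The unmeasured compound 4 `c1ccc(COc2ccc(OCCOCCOC3CCCC3)cc2)cc1` differs from compound 2 by cyclopentyloxy in place of cyclopentylamino on a saturated chain carbon, two bonds along the chain from an oxygen on a saturated carbon. Neither measured step makes this exchange: the step of an at least 4.0-fold lower number from compound 1 to compound 2 (0.60 log units; beyond the scatter) shows that what hangs on that amine nitrogen matters, while the step of a 1.2-fold lower number from compound 2 to compound 3 (0.09 log units; within the scatter) only puts a nitro in place of a hydrogen on an aromatic carbon and stays within the scatter. Within the data shown here, with no measured step that replaces the amine itself, a step within the scatter, in either direction, is expected. The change is expected to amount to a 1.2-fold higher number from compound 2 to compound 4 (0.08 log units; within the scatter). Compound 4 is therefore estimated at 30000 nM, between 10000 nM and 100000 nM.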

Compound 4, half-maximal inhibitory concentration: > 100000 nM
Compound 4: only a limit was reported; the forecaster's own chance of this, stated with the estimate: 20%; middle value at least 3.3-fold (0.52 log units) from the limit.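

In this assay, the step of an at least 4.0-fold higher number from compound 2 to compound 4 (0.60 log units; beyond the scatter) shows that the nitrogen on the saturated chain carbon counts in its own right, and not only what hangs on it. The cyclopentyl ring stays and the heavy-atom count is unchanged, so the exchange is nitrogen for oxygen, and the entering group carries no hydrogen-bond donor while the leaving group carries one. Compound 4 gives a limit of the assay and not a number: the limit of > 100000 nM in this assay, at which 2 of the 4 values shown sit.

Compound 1 and compound 4 both rest on limits, and the step between them cannot be read. As far as these compounds go, whether a methylated amine or an amide on the same chain carbon would keep the number of compound 2 stays open, and this single pair cannot say whether the missing hydrogen or something else about the oxygen lies behind the loss.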